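A Fluorinated Acid Side Chain and Its Half-Life

The source may report more compounds than this note shows. Statements on the series, on what has been measured and on what is new or still open speak of the compounds shown alone.

In an ADME assay on the whole organism (Rattus norvegicus, strain Sprague-Dawley) for metabolic stability, read by LC-MS, at a dose of 2 mg/kg by the intravenous route (on this read-out higher numbers stand for a longer-lived compound and lower numbers for a shorter-lived compound), compound 1 `COc1ccc(F)c([C@H]2CC[C@H](COc3cccc([C@H](C4CC4)[C@H](C)C(=O)O)c3)CC2)c1` gives 4.8 h and compound 2 `COc1ccc(F)c([C@H]2CC[C@H](COc3cccc([C@H](C4CC4)[C@@H](F)C(=O)O)c3)CC2)c1` gives 4.7 h, so compound 2 stands within the scatter of compound 1. Compound 3 `COc1ccc(F)c([C@H]2CC[C@H](COc3cccc([C@H](C4CC4)[C@@](C)(F)C(=O)O)c3)CC2)c1` carries 1-carboxy-1-fluoroethyl in place of carboxy(fluoro)methyl (1-carboxy-1-fluoroethyl in place of carboxy(fluoro)methyl on a saturated chain carbon bound to an aromatic carbon and a saturated ring carbon). For the measured compounds named here, the only measured step bearing on this change is a 1.0-fold lower number from compound 1 to compound 2 (0.01 log units; within the scatter), which exchanged 1-carboxyethyl for carboxy(fluoro)methyl at the same place. No shift beyond the scatter is therefore expected in this assay, and the expected step is a 1.1-fold higher number from compound 2 to compound 3 (0.04 log units; within the scatter). Compound 3 is estimated at 5.2 h, with an expected range of 3 h to 9 h.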

Compound 3, half-life: 4.3 h
For compound 3 the middle estimate is 1.2-fold (0.08 log units) above the measured one; low and high end bracket the measured number.
By their numbers in this assay, from the lowest: compounds 3, 2 and 1 (each within the scatter of the next).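

In this assay the new group shows a 1.1-fold lower number from compound 2 to compound 3 (0.04 log units; within the scatter) and a 1.1-fold lower number from compound 1 to compound 3 (0.05 log units; within the scatter) and both steps lie within the scatter. At this place, on a saturated chain carbon bound to an aromatic carbon and a saturated ring carbon, 1-carboxyethyl, carboxy(fluoro)methyl and 1-carboxy-1-fluoroethyl therefore give half-lives that cannot be told apart. Nothing at hand offers an explanation for this.

From the compounds shown here alone, whether carboxy(difluoro)methyl in place of carboxy(fluoro)methyl, or a primary amide in place of the carboxylic acid, would move the half-life beyond the scatter stays open.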